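Urea series: aryl swap at the benzylic ring

The source may report more compounds than this note shows. Statements on the series, on what has been measured and on what is new or still open speak of the compounds shown alone.

Measured so far:
compound 1 `Cc1cc(C)c(NC(=O)N(Cc2ccc(-c3ccccc3)s2)C2CCCCCC2)c(C)c1` 46 nM
compound 2 `Cc1cc(C)c(NC(=O)N(Cc2ccc(-c3nnc(C)o3)cc2)C2CCCCCC2)c(C)c1` 27 nM

Both compounds were run in an assay on microsomes from intestine for inhibition of acyl-CoA:cholesterol acyltransferase (Oryctolagus cuniculus); a lower number here means a stronger inhibitor, a higher number a weaker inhibitor. Compound 2 stands at the low end of the two numbers, with compound 1 close by; the gap between them lies within the scatter, so nothing separates them on this evidence.

Compound 3 `Cc1cc(C)c(NC(=O)N(Cc2ccc(-c3cccnc3)cc2)C2CCCCCC2)c(C)c1` has not been measured. It differs from compound 2 in one place: pyridin-3-yl in place of 5-methyl-1,3,4-oxadiazol-2-yl on an aromatic carbon. The shared core, the cycloheptyl group and the benzylic arm are unchanged; only the aromatic group para to a large group is exchanged.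

Going by the values given here, no step between measured compounds covers this exchange. Compound 1 and compound 2 carry different terminal aromatic groups yet sit within the scatter of each other, which suggests this part of the molecule tolerates variation. The step from compound 2 to compound 3 is therefore expected to be small, at most a modest rise in the number, and not clearly beyond the scatter: a 1.5-fold higher number from compound 2 to compound 3 (0.17 log units; within the scatter). For compound 3 the expected value in this assay is 40 nM, with a range from 15 nM to 110 nM.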

Compound 3, half-maximal inhibitory concentration: 130 nM
Beside the measured number, compound 3's estimate is 3.3-fold (0.51 log units) below it; the whole stated range lies below it.
By their numbers in this assay, from the lowest: compounds 2 and 1 (each within the scatter of the next); then compound 3.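

In this assay, pyridin-3-yl in place of 5-methyl-1,3,4-oxadiazol-2-yl on an aromatic carbon, para to a large group, gives a 4.8-fold higher number from compound 2 to compound 3 (0.68 log units; beyond the scatter), so this position is not indifferent to the aromatic group it carries. Going by these compounds alone, this is the only single-place reading at the position so far; compound 1 and compound 2 differ in more than one place, so their closeness within the scatter could not settle this. Both groups count 6 heavy atoms, while the five-membered aromatic ring with 3 hetero atoms gives way to a six-membered aromatic ring with 1 hetero atom, and nothing available bears on why the number rises.

Within the data shown here, the single exchange alters ring size, hetero atom count and the methyl group together, so the part of the change that carries the step remains unresolved. Open readings at this place include 1,3,4-oxadiazol-2-yl without its methyl group, which would isolate the methyl, and phenyl on the same benzylic ring, which would show the effect of a six-membered aromatic ring with no hetero atom.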